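Replacing a styryl arm with a trifluoromethoxyphenyl arm

The source may hold more compounds than are shown below. What is called first, only, known or untested is meant among the compounds shown, and "the series" means these compounds.

The measured compounds:
- compound 1 `COC(=O)/C=C/c1cccc(N(Cc2ccc(-c3c(OC)cccc3OC)cc2)C(=O)C2CCCCC2)c1`, an assay on isolated protein with Bile acid receptor (Homo sapiens) as the target; a higher number here means that more compound is needed for the effect, a lower number that less compound is needed: 77 nM
- compound 2 `COC(=O)/C=C/c1cccc(N(Cc2ccc(/C=C/c3ccc(OC)cc3)cc2)C(=O)C2CCCCC2)c1`, this assay: 208 nM

Within the data shown here, compound 2 holds the higher of the two numbers recorded in this assay; its nearest neighbour is compound 1, and the single step between them, a 2.7-fold higher number from compound 1 to compound 2 (0.43 log units; beyond the scatter), is the only comparison available. That step exchanged a directly attached 2,6-dimethoxyphenyl for a 2-(4-methoxyphenyl)ethenyl and raised the number beyond the scatter.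

Compound 3 `COC(=O)/C=C/c1cccc(N(Cc2ccc(-c3ccc(OC(F)(F)F)cc3)cc2)C(=O)C2CCCCC2)c1` differs from compound 2 in one place: 4-(trifluoromethoxy)phenyl in place of 2-(4-methoxyphenyl)ethenyl on an aromatic carbon. The change removes the ethenyl-linked aryl again and restores a directly attached phenyl ring, now carrying a trifluoromethoxy group rather than two methoxy groups. Among the measured compounds shown here, because the only relevant step, a 2.7-fold higher number from compound 1 to compound 2 (0.43 log units; beyond the scatter), went upward when the direct aryl was replaced by the ethenyl-linked aryl, the reverse kind of change is expected to bring the number back down in this assay, though the different substitution keeps this uncertain. Compound 3 is therefore estimated at 110 nM, within 40 nM to 300 nM, a step of a 1.9-fold lower number from compound 2 to compound 3 (0.28 log units; within the scatter).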

Compound 3, half-maximal effective concentration: 264 nM
Compound 3: middle estimate off by 2.4-fold (0.38 log units), on the low side; measured number inside the range.
By their numbers in this assay, from the lowest: compound 1; then compounds 2 and 3 (each within the scatter of the next).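

In this assay, a 1.3-fold higher number from compound 2 to compound 3 (0.10 log units; within the scatter), so at this position, on an aromatic carbon para to a large group, the 4-(trifluoromethoxy)phenyl and the 2-(4-methoxyphenyl)ethenyl arms cannot be told apart. The other comparison, a 3.4-fold higher number from compound 1 to compound 3 (0.54 log units; beyond the scatter), shows that a directly attached phenyl ring does not by itself go with the lower number of compound 1: compound 3 carries such a ring and goes against that reading, so the difference follows the 2,6-dimethoxyphenyl group of compound 1 among these three compounds. Nothing available here explains why these arms give these numbers.

The compounds shown leave open whether the number of compound 1 depends on both methoxy groups of its ring or on the direct attachment combined with just one of them, which a directly attached 4-methoxyphenyl or an unsubstituted phenyl would help to separate. They also leave open how this position responds to a carboxylic acid or an amine on the arm, since all three arms shown carry only ether-linked substituents or a carbon linker.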